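Same Bromine Step Tried on a Second Core

The compounds below may be only part of what the source reports. "The series", "measured", "known", "first", "only" and "open" are said of these compounds alone.

The measured compounds and their results:

compound 1, `COc1ccc2nc(-c3ccc(N/C=C\C(=O)c4cc(OC)c(OC)c(OC)c4)c(C)c3)sc2c1`, gives 17000 nM
compound 2, `COc1cc(OC)c2sc(-c3ccc(N/C=C\C(=O)c4cc(OC)c(OC)c(OC)c4Br)c(C)c3)nc2c1`, gives 17300 nM
compound 3, `COc1cc(OC)c2sc(-c3ccc(N/C=C\C(=O)c4cc(OC)c(OC)c(OC)c4)c(C)c3)nc2c1`, gives 13800 nM

All three were tested in a functional assay on MDA-MB-231 cells (Homo sapiens) for antiproliferative activity, read by sulforhodamine B assay, with a stated time of 48 h; a lower number here means a stronger inhibitor, a higher number a weaker inhibitor. Compound 3 and compound 2 differ in one place only, (bromo in place of hydrogen on an aromatic carbon), and this change gave a 1.3-fold higher number from compound 3 to compound 2 (0.10 log units; within the scatter). Compound 1 and compound 3 share the same right-hand part but carry different cores; the difference between the two cores is not broken down here. The numbers for compound 1 and compound 3 lie within the scatter of each other, so nothing can be said about which is stronger.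

Compound 4, `COc1ccc2nc(-c3ccc(N/C=C\C(=O)c4cc(OC)c(OC)c(OC)c4Br)c(C)c3)sc2c1`, has not yet been measured in this assay. It differs from compound 1 by bromo in place of hydrogen on an aromatic carbon, and the surroundings of the new group are described in the same words as for the change from compound 3 to compound 2, so this is the same change on a second core.

The step from compound 1 to compound 4 is expected to be about as small as the earlier one, a 1.1-fold higher number from compound 1 to compound 4 (0.05 log units; within the scatter), because the same change gave a 1.3-fold higher number from compound 3 to compound 2 (0.10 log units; within the scatter). Compound 4 is therefore estimated at 19000 nM in this assay, with a likely range from 9000 nM to 40000 nM.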

Compound 4, half-maximal inhibitory concentration: 9400 nM
Beside the measured number, compound 4's estimate is 2.0-fold (0.31 log units) above it, and the stated range covers the measured number.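

In this assay, going by these compounds alone, placing bromo in place of hydrogen on the aromatic carbon gives a 1.8-fold lower number from compound 1 to compound 4 (0.26 log units; within the scatter), so on this second core the change again produces no step that can be told apart from the ordinary spread of repeated measurements. Set side by side, the two steps agree as far as such data can tell: the same change on two cores in this assay, a 1.3-fold higher number (0.10 log units; within the scatter) from compound 3 to compound 2 and a 1.8-fold lower number (0.26 log units; within the scatter) from compound 1 to compound 4, 2.3-fold (0.36 log units) apart, within the scatter of two such steps. This shows that, across these two cores, the change carries over as a step too small to read, but it does not show that bromo has any real effect on either core, that the two cores truly respond alike, or that the same would hold on a further core, since the whole comparison rests on just two matched pairs in one assay.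

The compounds shown leave open whether a different group on the same aromatic carbon, such as fluoro, an amine or a carboxylic acid, would produce a step large enough to stand clear of the scatter. They also leave open whether the bromo step would stay this small on a third core, or in a test on a different kind of cell.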